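This account rests on a few compounds, and the source may have more. Where it says the series, first, only, none or still open, it means among the compounds named here.

Measured compounds on hand:
- compound 1 `CC(C)(C)c1ccc(CNCCCNS(=O)(=O)c2cc(C(F)(F)F)cc(C(F)(F)F)c2)cc1`: 1400 nM
- compound 2 `O=S(=O)(NCCCNCc1cccc2ccccc12)c1cc(C(F)(F)F)cc(C(F)(F)F)c1`: 2700 nM

Both were run in a functional assay on BXPC-3 cells (Homo sapiens) for inhibition, read by MTT assay, with a stated time of 72 h; on this read-out higher numbers stand for weaker inhibition of growth and lower numbers for stronger inhibition of growth. Among the compounds with values here, compound 1 gives 1400 nM and compound 2 gives 2700 nM, so compound 2 carries the highest of the two numbers, with compound 1 as its only neighbour; the step of a 1.9-fold higher number from compound 1 to compound 2 (0.29 log units; within the scatter) lies within the scatter, so no order between the two can be claimed.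

Compound 3 `COc1ccc(CNCCCNS(=O)(=O)c2cc(C(F)(F)F)cc(C(F)(F)F)c2)cc1` is not yet measured in this assay. It differs from compound 2 by 4-methoxyphenyl in place of naphthalen-1-yl on a saturated chain carbon bound to an amine nitrogen; the same difference, cut one bond further out, reads (naphthalen-1-yl)methyl to 4-methoxybenzyl. Within the data shown here, the only step on hand that touches this position is a 1.9-fold higher number from compound 1 to compound 2 (0.29 log units; within the scatter), an exchange of one aryl group for another at the same place that stayed within the scatter. Among the measured compounds shown here, no measured pair covers a 4-methoxyphenyl group, so the new acceptor has no precedent here. On this basis the expected step of a 1.1-fold lower number from compound 2 to compound 3 (0.03 log units; within the scatter) is small, with no direction claimed beyond the scatter. Compound 3 is therefore estimated at 2500 nM, in the range 900 nM to 7000 nM.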

Compound 3, concentration for 50% growth inhibition: 1300 nM
For compound 3 the middle estimate is 1.9-fold (0.28 log units) above the measured one, within the range that was stated.
By their numbers in this assay, from the lowest: compounds 3, 1 and 2 (each within the scatter of the next, the first and the last beyond it).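

In this assay the aryl exchange on a saturated chain carbon bound to an amine nitrogen now gives a step beyond the scatter, though a modest one: a 2.1-fold lower number from compound 2 to compound 3 (0.32 log units; beyond the scatter) with 4-methoxyphenyl in place of naphthalen-1-yl. Methoxy in place of tert-butyl on an aromatic carbon gives a 1.1-fold lower number from compound 1 to compound 3 (0.03 log units; within the scatter) and stays within the scatter, so these two substituted phenyl groups are not told apart on this read-out, while compound 1 goes against any simple rule based on ring count, since a 1.9-fold higher number from compound 1 to compound 2 (0.29 log units; within the scatter) also stays within the scatter despite the same change from one aromatic ring to two. Nothing on hand offers an explanation for any of these steps.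

The step from compound 2 to compound 3 changes the ring count and brings in the methoxy oxygen together, and a plain phenyl group at this place would be needed to separate the two. Going by these compounds, how far the tolerance at this place extends also stays open, for instance to a pyridyl group, to a hydroxy or amino group on the ring, or to a longer chain in the core.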